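Clearance of a Methyl-Branched Acid Chain

The source may report more compounds than this note shows. Statements on the series, on what has been measured and on what is new or still open speak of the compounds shown alone.

Compound 1 `CN(Cc1ccccc1OCCCCCC(=O)O)C(=O)c1ccc(-c2ccco2)cc1`: 44 mL/min/kg
Compound 2 `CN(Cc1ccccc1OCCC/C=C/C(=O)O)C(=O)c1ccc(-c2ccco2)cc1`: 67 mL/min/kg

In an ADME assay on the whole organism (strain CD-1) for pharmacokinetics, with Mus musculus as the target, at a dose of 3 mg/kg by the intravenous route (a higher number here means faster removal of the compound, a lower number slower removal), compound 2 gives 67 mL/min/kg, which lies within the scatter of compound 1. Compound 3 `CC(CCOc1ccccc1CN(C)C(=O)c1ccc(-c2ccco2)cc1)CCC(=O)O` differs from compound 2 by 3-carboxy-1-methylpropyl in place of 3-carboxyprop-2-en-1-yl on a saturated chain carbon, two bonds along the chain from an oxygen on an aromatic ring, on a saturated chain carbon, two bonds along the chain from an oxygen on an aromatic ring. Going by the values given here, the only measured step, a 1.5-fold higher number from compound 1 to compound 2 (0.18 log units; within the scatter), also alters this chain and stays within the scatter. No change beyond the scatter is therefore expected in this assay. The expected step is a 1.3-fold lower number from compound 2 to compound 3 (0.11 log units; within the scatter). Compound 3 is estimated at 52 mL/min/kg, with an expected range of 26 mL/min/kg to 100 mL/min/kg.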

Compound 3, clearance: 4 mL/min/kg
Compound 3: the middle estimate sits 13-fold (1.11 log units) above what was measured, and the stated range ends above it.
By their numbers in this assay, from the lowest: compound 3; then compounds 1 and 2 (each within the scatter of the next).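

In this assay this chain proved far more sensitive than the first pair suggested: methyl in place of hydrogen on a saturated chain carbon bound to two saturated chain carbons gives a large step (an 11-fold lower number from compound 1 to compound 3 (1.04 log units; beyond the scatter)), and 3-carboxy-1-methylpropyl in place of 3-carboxyprop-2-en-1-yl gives another (a 17-fold lower number from compound 2 to compound 3 (1.22 log units; beyond the scatter)). A single added methyl thus moved the number beyond the scatter, which the change from compound 1 to compound 2 had not done. Nothing available explains why. Open, as far as these compounds go, is whether an ethyl or a second methyl on that carbon would keep the number of compound 3, and whether the two mirror-image forms of compound 3 behave alike.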